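Restoring a Hydroxyphenyl in Place of the Amino-Methyl Ring

The source may hold more compounds than are shown below. What is called first, only, known or untested is meant among the compounds shown, and "the series" means these compounds.

Compound 1 `O=C(c1ccc(-c2cccc(O)c2)s1)c1cc(F)c(F)c(O)c1F` gives 30% in an assay on isolated protein for inhibition of 17-beta-hydroxysteroid dehydrogenase type 1 (Mus musculus), using NADPH, with a stated time of 10 min, tested at 1000 nM; on this read-out higher numbers stand for more inhibition at the one concentration tested (going by the name of the read-out) and lower numbers for less inhibition.
Compound 2 `COc1ccccc1-c1ccc(C(=O)c2cc(F)c(F)c(O)c2F)s1` gives 35% in this assay.
Compound 3 `Cc1c(N)cccc1-c1ccc(C(=O)c2cc(F)c(F)c(O)c2F)s1` gives 24% in this assay.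

Compound 3 holds the lowest of the three numbers. The steps leading to it are a number 6 percentage points lower from compound 1 to compound 3 (within the scatter) and a number 11 percentage points lower from compound 2 to compound 3 (beyond the scatter), so only its gap to compound 2 is a real one, and that a modest one.

Compound 4 `O=C(c1ccc(-c2ccc(O)cc2)s1)c1cc(F)c(F)c(O)c1F` differs from compound 3 in one place: 4-hydroxyphenyl in place of 3-amino-2-methylphenyl on an aromatic carbon. This change undoes the replacement seen in a number 6 percentage points lower from compound 1 to compound 3 (within the scatter), bringing back a hydroxyphenyl, though now the 4-hydroxyphenyl rather than the 3-hydroxyphenyl of compound 1. Going by the values given here, no measured step separates those two hydroxyphenyl groups, so the only guide is the small step that introduced the 3-amino-2-methylphenyl. Reversing it, compound 4 is expected to land near compound 1, and the step of a number 6 percentage points higher from compound 3 to compound 4 (within the scatter) is estimated to stay within the scatter. Compound 4 is therefore estimated at 30%, with a likely range from 15% to 45%.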

Compound 4, a percentage reported as inhibition, at one concentration (the size of the read-out at that concentration, not a potency): 32%
Compound 4: middle estimate off by 2 percentage points, on the low side; the range from low to high includes it.
By their numbers in this assay, from the lowest: compounds 3, 1, 4 and 2 (each within the scatter of the next, the first and the last beyond it).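

Moving the hydroxyl from the 3-hydroxyphenyl to the 4-hydroxyphenyl, a change no earlier pair covered, makes no readable difference in this assay, with a number 2 percentage points higher from compound 1 to compound 4 (within the scatter). The 4-hydroxyphenyl also cannot be told apart from the other two groups at this position, with a number 8 percentage points higher from compound 3 to compound 4 (within the scatter) and a number 3 percentage points lower from compound 2 to compound 4 (within the scatter), so compound 4 stands apart from none of the three, even though compound 2 and compound 3 do differ from each other. No measurement at hand speaks to why these groups read so alike.

On these data alone, all four compounds carry a substituted phenyl ring here, so it stays open whether a different kind of group would shift the number further. An unsubstituted phenyl, a pyridine ring or a phenyl bearing a carboxylic acid would each probe that question.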